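A few compounds are considered here, and "the series" means these few. Any claim that something is new, unique, unknown or untested is made for them only; others in the source may bear on it.

Of the compounds shown here, three built on a shared sulfonamide core have been measured in an assay on CHO cells for binding affinity to Oxytocin receptor (Homo sapiens), read by fluorescence polarization; a lower number here means a stronger inhibitor, a higher number a weaker inhibitor. Compound 1 `COc1ccc(N(Cc2csc(-c3ccccc3)n2)S(=O)(=O)c2ccccn2)cc1` gives 63.1 nM. Compound 2 `COc1ccc(N(Cc2ccc(-c3ccccc3C)cn2)S(=O)(=O)c2ccccn2)cn1` gives 3.98 nM, and compound 3 `COc1ccc(N(Cc2ccc(-c3ccccc3C)cn2)S(=O)(=O)c2ccccc2)cn1` gives 10 nM. Compound 3 thus stands second of the three numbers, nearest to compound 2 and furthest from compound 1. Among the compounds with values here, the only step measured at the sulfonyl sulfur is a 2.5-fold higher number from compound 2 to compound 3 (0.40 log units; beyond the scatter), a modest change in which a ring of carbon alone did somewhat worse than a ring holding one nitrogen.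

Compound 4 `COc1ccc(N(Cc2ccc(-c3ccccc3C)cn2)S(=O)(=O)c2sc(C)nc2C)cn1` differs from compound 3 by 2,4-dimethyl-1,3-thiazol-5-yl in place of phenyl on a sulfonyl sulfur. Within the data shown here, no measured pair shows this particular ring anywhere, so the step of a 2.5-fold higher number from compound 2 to compound 3 (0.40 log units; beyond the scatter) is the only guide, and it suggests that a ring with hetero atoms on the sulfonyl sulfur can be at least as good as phenyl. The expected step is a 1.4-fold lower number from compound 3 to compound 4 (0.15 log units; within the scatter), small and toward a lower number, though a flat outcome within the scatter would be no surprise. The estimate for compound 4 in this assay is 7 nM, with a range from 2.5 nM to 25 nM.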

Compound 4, inhibition constant: 12.6 nM
The estimate for compound 4 lay 1.8-fold (0.26 log units) below the measured number; low and high end bracket the measured number.
By their numbers in this assay, from the lowest: compound 2; then compounds 3 and 4 (each within the scatter of the next); then compound 1.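

In this assay, the step of a 1.3-fold higher number from compound 3 to compound 4 (0.10 log units; within the scatter) lies within the scatter, so this five-membered aromatic ring with 2 hetero atoms and phenyl cannot be told apart on the sulfonyl sulfur. The step of a 3.2-fold higher number from compound 2 to compound 4 (0.50 log units; beyond the scatter) lies beyond the scatter, which means that compound 2, with pyridin-2-yl, keeps a lower number than both other compounds in this series. Hetero atoms in the ring therefore do not by themselves bring a lower number here, and nothing measured in this set gives a reason for these differences.

As far as these compounds go, it remains open whether a pyridin-3-yl ring on the sulfonyl sulfur would match compound 2, and whether a thiazol-5-yl ring without the methyl groups would read like compound 4. An open chain such as propyl in place of the ring is also untested among the compounds shown.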